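This account rests on a few compounds, and the source may have more. Where it says the series, first, only, none or still open, it means among the compounds named here.

Among the compounds with values here, in a physicochemical assay for lipophilicity, at pH 7.4 (on this read-out higher numbers stand for higher lipophilicity and lower numbers for lower lipophilicity), compound 2 (`CNC(=O)c1cc(C(=O)N[C@H]2[C@@H]3COC[C@@H]32)cc2c1OC[C@H]2c1ccccc1`) gives 3.3, the middle of the three numbers so far. Compound 1 (`CNC(=O)c1cc(C(=O)N[C@H]2[C@@H]3COC[C@@H]32)cc2c1OC[C@H]2c1cccc2[nH]ccc12`) gives 3.1 and compound 3 (`CNC(=O)c1cc(C(=O)Nc2cnn(C)c2)cc2c1OC[C@H]2c1ccccc1`) gives 3.5, both within the scatter of compound 2. Compound 4 (`CNC(=O)c1cc(C(=O)N[C@H]2[C@@H]3COC[C@@H]32)cc2c1OC[C@H]2c1ccccn1`) carries one change from compound 2, (pyridin-2-yl in place of phenyl on a saturated ring carbon), in words pyridin-2-yl in place of phenyl on a saturated ring carbon. At that same carbon the measured change was a number 0.20 log units higher from compound 1 to compound 2 (within the scatter), and on the amide-type nitrogen it was a number 0.20 log units higher from compound 2 to compound 3 (within the scatter). Neither exchange is this one, so both set only a loose guide. From the structural change itself, a downward move beyond the scatter is expected, a number 0.70 log units lower from compound 2 to compound 4 (beyond the scatter). For compound 4 the estimated value is 2.6, with an expected range from 2.2 to 3.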

Compound 4, distribution coefficient: 1.6
Estimate against measurement, compound 4: 1.00 log units above, outside the stated range (below it).
By their numbers in this assay, from the lowest: compound 4; then compounds 1, 2 and 3 (each within the scatter of the next, the first and the last beyond it).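

At this saturated ring carbon, the change from phenyl to pyridin-2-yl moves this assay by a large amount (a number 1.70 log units lower from compound 2 to compound 4 (beyond the scatter)), so this position is not as flat as the earlier exchange there suggested (a number 0.20 log units higher from compound 1 to compound 2 (within the scatter)). Pyridin-2-yl in place of 1H-indol-4-yl gives a large step as well (a number 1.50 log units lower from compound 1 to compound 4 (beyond the scatter)). Nothing available explains the size of these steps. The compounds shown leave open whether pyridin-3-yl or pyridin-4-yl at this carbon would give a similar step. They also leave open whether the exchange keeps its size with the amide-nitrogen group of compound 3.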